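Swapping a Small Chain for a Bromobenzyl Arm

A few compounds are considered here, and "the series" means these few. Any claim that something is new, unique, unknown or untested is made for them only; others in the source may bear on it.

Within the data shown here, in a functional assay on PC-3 cells (Homo sapiens) for antiproliferative activity, read by MTT assay, with a stated time of 48 h (on this read-out lower numbers stand for stronger inhibition and higher numbers for weaker inhibition), compound 3 `CCN1C(=O)C(O)(Cc2nnn[nH]2)c2cc(Cl)ccc21` gives 79300 nM, the only actual number among the three measured compounds. Compound 2 `CN1C(=O)C(O)(Cc2nnn[nH]2)c2cc(Cl)ccc21` reaches only the limit of the assay, > 100000 nM. Compound 1 `O=C1N(Cc2ccc(Br)cc2)c2ccc(F)cc2C1(O)Cc1nnn[nH]1` likewise sits at a limit, > 100000 nM. Among the measured compounds shown here, the one measured step, an at least 1.2-fold lower number from compound 2 to compound 3 (0.10 log units; that floor lies within the scatter), is small and lies within the scatter, so the three measured compounds together show little more than the limit of > 100000 nM in this assay, at which 2 of the 3 values shown sit.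

Compound 4 `O=C1N(Cc2ccc(Br)cc2)c2ccc(Cl)cc2C1(O)Cc1nnn[nH]1` differs from compound 3 by 4-bromophenyl in place of methyl on a saturated chain carbon bound to an amide-type nitrogen in a ring. For the measured compounds named here, no measured step covers a change of this kind, and the most closely related measured compound is compound 1, which also carries a 4-bromobenzyl group and returns a limit rather than a number. Compound 4 is therefore expected to land near or beyond that limit, with the estimated change a 1.9-fold higher number from compound 3 to compound 4 (0.28 log units; within the scatter) pointing toward a higher number. Compound 4 is estimated at 150000 nM, within an expected range from 40000 nM to 600000 nM.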

Compound 4, half-maximal inhibitory concentration: 87900 nM
Estimate against measurement, compound 4: 1.7-fold (0.23 log units) above; low and high end bracket the measured number.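

In this assay, the step from ethyl to 4-bromobenzyl at this position, which brings in an aromatic ring, is a 1.1-fold higher number from compound 3 to compound 4 (0.04 log units; within the scatter), so this arm gives a second actual number but no change that can be told from scatter. Two further steps give only floors: with the arm kept, chloro in place of fluoro on an aromatic carbon gives an at least 1.1-fold lower number from compound 1 to compound 4 (0.05 log units; that floor lies within the scatter), and the wider change at the same position gives an at least 1.1-fold lower number from compound 2 to compound 4 (0.05 log units; that floor lies within the scatter). Neither floor tells how far apart those compounds really lie: the limit of > 100000 nM in this assay, at which 2 of the 4 values shown sit.

Going by these compounds, whether a plain benzyl without the bromine, or a chain ending in an amine or a carboxylic acid, would move the number beyond the scatter at this position stays open. So does the effect of a methoxy group on that aromatic carbon in place of chloro or fluoro.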